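Working notes: adding trifluoromethyl to compound 2

The compounds below may be only part of what the source reports. "The series", "measured", "known", "first", "only" and "open" are said of these compounds alone.

Measured so far in a functional assay with Homo sapiens as the target; on this read-out higher numbers stand for weaker inhibition and lower numbers for stronger inhibition:
- compound 1 `CC(C)[C@H](NC(=O)COc1cccc2ccccc12)C(=O)N[C@@H](CC(=O)O)C(=O)COc1ccccc1`: 11200 nM
- compound 2 `CC(C)[C@H](NC(=O)COc1cccc2ccccc12)C(=O)N[C@@H](CC(=O)O)C(=O)COc1ccc(Oc2ccccc2)cc1`: 19000 nM

Among the compounds with values here, only two numbers exist for this series. Compound 2 gives 19000 nM, which lies within the scatter of compound 1 at 11200 nM, so neither compound can be ranked over the other.

The next compound is compound 3 `CC(C)[C@H](NC(=O)COc1cccc2ccccc12)C(=O)N[C@@H](CC(=O)O)C(=O)COc1ccc(Oc2ccc(C(F)(F)F)cc2)cc1`. It differs from compound 2 by trifluoromethyl in place of hydrogen on an aromatic carbon, para to a large group, which reads as phenoxy to 4-(trifluoromethyl)phenoxy.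

Within the data shown here, no measured step introduces trifluoromethyl. Among the measured compounds shown here, the one step that bears on this change is a 1.7-fold higher number from compound 1 to compound 2 (0.23 log units; within the scatter), with phenoxy in place of hydrogen on an aromatic carbon, and it stayed within the scatter. On the strength of that single step from compound 1 to compound 2, no shift beyond the scatter is expected in this assay, and no direction can be favoured.

The expected step is a 1.1-fold higher number from compound 2 to compound 3 (0.02 log units; within the scatter).

For compound 3 the estimated value is 20000 nM, with an expected range from 8000 nM to 45000 nM.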

Compound 3, half-maximal inhibitory concentration: 24900 nM
Estimate against measurement, compound 3: 1.2-fold (0.10 log units) below, and the stated range covers the measured number.
By their numbers in this assay, from the lowest: compounds 1, 2 and 3 (each within the scatter of the next, the first and the last beyond it).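

In this assay, the step of a 1.3-fold higher number from compound 2 to compound 3 (0.12 log units; within the scatter) adds trifluoromethyl to the outer aromatic carbon of the phenoxy group, and on its own this change does not separate compound 3 from compound 2. Within the data shown here, the larger comparison, a 2.2-fold higher number from compound 1 to compound 3 (0.35 log units; beyond the scatter), is the first step to pass beyond the scatter: the full 4-(trifluoromethyl)phenoxy group in place of hydrogen is modestly weaker than the unsubstituted compound, although neither of the two smaller steps leading to it can be read alone, so at this position the series so far shows only a small loss that becomes visible when the two additions are taken together. Nothing available accounts for this shift.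

The compounds shown leave open whether an amine, a carboxylic acid or a hydroxyl group on the same aromatic carbon, in place of trifluoromethyl, would give a lower number in this assay. They also leave open whether a short chain such as methoxy, or a single fluorine, in place of the whole phenoxy group would do so, and whether the modest loss would recur with a different group elsewhere on the shared core.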